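Working notes: thiophene for chlorophenyl on the amide alkene

A few compounds are considered here, and "the series" means these few. Any claim that something is new, unique, unknown or untested is made for them only; others in the source may bear on it.

Measured so far in a functional assay on B16-F10 cells (Mus musculus) for inhibition, read by MTT assay, with a stated time of 48 h; a higher number here means a weaker inhibitor, a lower number a stronger inhibitor:
compound 1 `O=C(/C=C/c1ccccc1)Nc1ccc2ncnc(Nc3cccc(Br)c3)c2c1`, 1.45 ug/mL
compound 2 `O=C(/C=C/c1ccccc1Cl)Nc1ccc2ncnc(Nc3cccc(Br)c3)c2c1`, 2 ug/mL
compound 3 `O=C(/C=C/c1ccccc1Cl)Nc1ccc2ncnc(Nc3cccc(Cl)c3)c2c1`, 1.74 ug/mL

Compound 3 stands second highest of the three numbers; its nearest neighbour is compound 2 and its furthest is compound 1, and both gaps lie within the scatter, so no order can be read among the three. Compound 4 `O=C(/C=C/c1cccs1)Nc1ccc2ncnc(Nc3cccc(Cl)c3)c2c1` is not yet measured. Its difference from compound 3 is thiophen-2-yl in place of 2-chlorophenyl on a double-bonded chain carbon bound to a double-bonded chain carbon.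

Two steps are available. The step of a 1.4-fold higher number from compound 1 to compound 2 (0.14 log units; within the scatter) concerns the ring that leaves in compound 4, but it adds a chloro rather than exchanging the whole ring. The step of a 1.1-fold lower number from compound 2 to compound 3 (0.06 log units; within the scatter) concerns the ring that carries the bromo or chloro and does not touch the changed site. For the measured compounds named here, neither is a direct precedent for exchanging a chlorophenyl for a thiophenyl; both were within the scatter, and no step in this set exceeds it. The expected step in this assay is therefore a 1.1-fold lower number from compound 3 to compound 4 (0.04 log units; within the scatter), that is, no change beyond the scatter in either direction. Compound 4 is estimated at 1.6 ug/mL in this assay, with a range from 0.7 ug/mL to 3.5 ug/mL.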

Compound 4, half-maximal inhibitory concentration: 4.26 ug/mL
The estimate for compound 4 lay 2.7-fold (0.43 log units) below the measured number; the measured number lies above the stated range.
By their numbers in this assay, from the lowest: compounds 1, 3 and 2 (each within the scatter of the next); then compound 4.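

In this assay, for the compounds shown here, the exchange of 2-chlorophenyl for thiophen-2-yl on the double-bonded chain carbon gives a 2.4-fold higher number from compound 3 to compound 4 (0.39 log units; beyond the scatter) and is the only step in this set printed as beyond the scatter, though a modest one. The earlier change at this ring, chloro in place of hydrogen, gave a 1.4-fold higher number from compound 1 to compound 2 (0.14 log units; within the scatter) and so showed no response, whereas replacing the whole ring shows that this position is not indifferent to what sits on the chain. Nothing in the available data accounts for the step.

The single exchange alters the ring size, brings in sulfur and removes the chloro all at once, and the compounds shown do not separate these three differences, so which of them carries the step remains open. Also open, on these data alone, is how a furan-2-yl or pyridin-2-yl ring, or an amine carried on the thiophen-2-yl ring, would read at this place, and whether the step would hold with bromo in place of chloro on the other ring of the series.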